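From Chloro to Butyl: What to Expect for Compound 4

The source may hold more compounds than are shown below. What is called first, only, known or untested is meant among the compounds shown, and "the series" means these compounds.

For the measured compounds named here, in a functional assay on MCF7 cells (Homo sapiens) for antiproliferative activity, read by MTT assay, with a stated time of 96 h (a higher number here means a weaker inhibitor, a lower number a stronger inhibitor), compound 1 `O=C1C2=C(C(=O)c3ncccc31)C1(CS2)NC(=O)N(c2ccc(Cl)cc2)C1=O` gives 4 nM, the lowest of the three numbers measured so far. Compound 3 `O=C1NN(c2ccc(Cl)cc2)C(=O)C2(CSC3=C2C(=O)c2ncccc2C3=O)N1` gives 110 nM, and compound 2 `Cc1ccc(N2NC(=O)NC3(CSC4=C3C(=O)c3ncccc3C4=O)C2=O)cc1` gives 410 nM. Compound 4 `CCCCc1ccc(N2C(=O)NC3(CSC4=C3C(=O)c3ncccc3C4=O)C2=O)cc1` differs from compound 1 in one place: butyl in place of chloro on an aromatic carbon. Going by the values given here, only one measured step bears on this change, and it runs in the opposite direction: a 3.7-fold lower number from compound 2 to compound 3 (0.57 log units; beyond the scatter). Read backwards, putting methyl where chloro stood brought a modestly higher number there, though butyl is not methyl, and compounds 2 and 3 share a core that differs from that of compound 1. The expectation for compound 4 is therefore a modestly higher number, a 5.0-fold higher number from compound 1 to compound 4 (0.70 log units; beyond the scatter). Compound 4 is estimated at 20 nM, within a range of 5 nM to 100 nM.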

Compound 4, half-maximal inhibitory concentration: 70 nM
Compound 4: the middle estimate sits 3.5-fold (0.54 log units) below what was measured, within the range that was stated.
By their numbers in this assay, from the lowest: compound 1; then compounds 4 and 3 (each within the scatter of the next); then compound 2.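

For the compounds shown here, on the core of compound 1, the change from 4-chlorophenyl to 4-butylphenyl gives an 18-fold higher number from compound 1 to compound 4 (1.24 log units; beyond the scatter) in this assay, a large loss rather than the modest one seen on a different core, where a 3.7-fold lower number from compound 2 to compound 3 (0.57 log units; beyond the scatter) was the only guide. Chloro thus gives the lower number on both cores, and the gap is wider on this one. Nothing measured here accounts for the rise. Still open, from the compounds shown here alone, is whether ethyl, a shorter chain, would fall between chloro and butyl at this position. An amine or a carboxylic acid there also remains untested in the compounds shown.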